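Trading a methyl for an amide on the ring nitrogen

The source may report more compounds than this note shows. Statements on the series, on what has been measured and on what is new or still open speak of the compounds shown alone.

Compound 1, `O=C1c2sc(C#Cc3ccccc3)nc2CN1C1CC1`, gives > 10000 nM, which is a limit of the assay and not a number.
Compound 2, `CN1CCc2nc(C#Cc3ccccc3)sc2C1`, gives 34 nM.
Compound 3, `CN1CCc2nc(C#Cc3cccc(F)c3)sc2C1`, gives > 10000 nM, again a limit of the assay rather than a number.

All three were measured in an assay on HEK293 cells for positive allosteric modulation of metabotropic glutamate receptor 5 (Homo sapiens), read by FLIPR, with a stated time of 1 h; on this read-out higher numbers stand for an effect only at larger amounts of compound and lower numbers for an effect already at smaller amounts. Compound 3 stands at the limit: its value is a limit of the assay, not a number, and it shares that position with compound 1 (the limit of > 10000 nM in this assay, at which 2 of the 3 values shown sit). Within the data shown here, the only single-point step among the measured compounds runs from compound 2 to compound 3, an at least 290-fold higher number from compound 2 to compound 3 (2.46 log units; beyond the scatter), where the change is fluoro in place of hydrogen on an aromatic carbon.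

Compound 4, `O=C(C1CC(F)(F)C1)N1CCc2nc(C#Cc3cccc(F)c3)sc2C1`, differs from compound 3 by (3,3-difluorocyclobutyl)carbonyl in place of methyl on an amine nitrogen in a ring. Among the measured compounds shown here, no measured step touches the ring nitrogen, so nothing among the measured compounds speaks to this change directly; compound 1 carries a carbonyl on its ring nitrogen and sits at the limit, but it is not a single-point neighbour of compound 3 or compound 4. Because compound 3 is itself a limit > 10000 nM, the starting point is uncertain. For compound 4 the expected value is 5000 nM, with a range from 300 nM to 30000 nM, and the expected step is an at least 2.0-fold lower number from compound 3 to compound 4 (0.30 log units; that floor lies within the scatter), with a real chance that only a limit is reported again.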

Compound 4, half-maximal effective concentration: 2.5 nM
Beside the measured number, compound 4's estimate is 2000-fold (3.30 log units) above it, and the stated range ends above it.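

In this assay, among these compounds, the ring nitrogen now has a measured step of its own, an at least 4000-fold lower number from compound 3 to compound 4 (3.60 log units; beyond the scatter), and this position proves able to carry a very large change in the read-out, which no earlier pair could show. Compound 3, with fluoro on the aromatic carbon and methyl on the nitrogen, sits at a limit of the assay. The result also shows that this fluoro does not rule out a low number once (3,3-difluorocyclobutyl)carbonyl takes the place of that methyl: compound 4 carries the same fluoro and gives 2.5 nM. The size of the step is only a floor, since the value of compound 3 is a limit of the assay and not a number: the limit of > 10000 nM in this assay, at which 2 of the 4 values shown sit.

The change swaps methyl for the whole (3,3-difluorocyclobutyl)carbonyl group at once, and the compounds shown do not separate the part played by the carbonyl from that of the ring or its two fluorines, as a plain acetyl or an unfluorinated cyclobutylcarbonyl on the same nitrogen could. Also open is how this group on the nitrogen behaves with hydrogen in place of the fluoro on the aromatic carbon, a pairing that none of the compounds shown carries.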